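One Methyl More on the Amide Nitrogen

The source may hold more compounds than are shown below. What is called first, only, known or untested is meant among the compounds shown, and "the series" means these compounds.

Three compounds share one core and differ only in the arm attached to it. Compound 1 `CN(C)/C(=N\C#N)C1=CC(C)(C)Oc2ccc([N+](=O)[O-])cc21` appears in the study, but in a functional assay on the whole organism (aorta) with Rattus norvegicus as the target (on this read-out lower numbers stand for smaller maximal responses and higher numbers for larger maximal responses), compound 1 gives "nt" (no result reported), that is, no result was reported for it. Going by the values given here, compound 2 `CNC(=O)C1=CC(C)(C)Oc2ccc([N+](=O)[O-])cc21` is the single compound with a number: in this assay compound 2 gives 61%. Among the compounds with values here, that is where compound 2 stands, as the only measured value among the three, with no partner to set it against. Compound 3 `CN(C)C(=O)C1=CC(C)(C)Oc2ccc([N+](=O)[O-])cc21` differs from compound 2 in one place: methyl in place of hydrogen on an amide-type nitrogen. The amide hydrogen of compound 2 gives way to a methyl, so that methylcarbamoyl becomes dimethylcarbamoyl.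

Within the data shown here, no measured pair shows what such a change does in this assay, so any expectation rests on the one value of compound 2 and on the change itself. A moderate downward step is expected, a number 16 percentage points lower from compound 2 to compound 3 (beyond the scatter), somewhat beyond the usual scatter but far from a loss of the response. For compound 3 the estimated maximal response is 45%, with a range from 20% to 75%.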

Compound 3, intrinsic activity: the largest response reached, in percent of the reference agonist's: 79.9%
For compound 3 the middle estimate is 34.9 percentage points below the measured one; measured number outside the range, above it.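

The change from methylcarbamoyl to dimethylcarbamoyl gives, in this assay, a number 18.9 percentage points higher from compound 2 to compound 3 (beyond the scatter). This first measured pair shows that the amide-type nitrogen can lose its hydrogen to a methyl with no loss of maximal response, and that this single added carbon is enough to move the response by more than repeated measurements usually scatter. Nothing in the data shown explains why the added methyl goes with a larger maximal response.

In this assay compound 1 gives "nt" (no result reported), so any step involving compound 1 cannot be read, and the arm of compound 1 stays unplaced relative to the two amides. The rise also rests on one pair in one assay, which leaves open whether an unsubstituted carbamoyl group, with two hydrogens on the nitrogen, would fall below compound 2, and whether a longer chain such as diethylcarbamoyl would carry the response further or lose it.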